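The compounds below may be only part of what the source reports. "The series", "measured", "known", "first", "only" and "open" are said of these compounds alone.

Series notes, step from compound 3 to compound 4. Within the data shown here, compound 3 `Cc1cc(Cl)ccc1-c1cc2c(cn1)ncn2-c1ccc(OC(F)F)cc1` gives 28 nM in a functional assay on HL-60 cells (Homo sapiens) for activation, read by flow cytometry, with a stated time of 4 days (on this read-out higher numbers stand for an effect only at larger amounts of compound and lower numbers for an effect already at smaller amounts), and stands lowest of the three numbers measured so far. Compound 2 `Cc1cccc(C)c1-c1cc2c(cn1)ncn2-c1ccc(OC(F)F)cc1` gives 980 nM, and compound 1 `Fc1ccc(-c2cc3c(cn2)ncn3-c2ccc(OC(F)F)cc2)cc1` gives 10000 nM. The measured steps are a 10-fold lower number from compound 1 to compound 2 (1.01 log units; beyond the scatter), a 360-fold lower number from compound 1 to compound 3 (2.55 log units; beyond the scatter) and a 35-fold lower number from compound 2 to compound 3 (1.54 log units; beyond the scatter); all three are large and all concern the same aromatic carbon, so the group at this place moves the read-out widely.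

Compound 4 `Cc1nc(F)ccc1-c1cc2c(cn1)ncn2-c1ccc(OC(F)F)cc1` is not yet measured. The change is 6-fluoro-2-methylpyridin-3-yl in place of 4-chloro-2-methylphenyl on an aromatic carbon. Among the measured compounds shown here, no measured step matches this exchange on its own. For the measured compounds named here, the steps that bear on it are the three above. Compound 3, with 4-chloro-2-methylphenyl, gives the lowest number, while compound 1, with 4-fluorophenyl and no methyl group, stands far higher; compound 1 differs from compound 3 in more than one respect, so the share of the chlorine and of the methyl group cannot be separated. Compound 4 keeps the methyl group and exchanges the remainder of the ring, so a step toward higher numbers of moderate size is expected in this assay, with wide uncertainty.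

Compound 4 is expected to give 110 nM, within 25 nM to 600 nM. That estimate corresponds to a 3.9-fold higher number from compound 3 to compound 4 (0.59 log units; beyond the scatter).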

Compound 4, half-maximal effective concentration: 2000 nM
For compound 4 the middle estimate is 18-fold (1.26 log units) below the measured one; measured number above the stated range.
By their numbers in this assay, from the lowest: compound 3; then compound 2; then compound 4; then compound 1.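

In this assay the methyl group shared by compound 3 and compound 4 does not preserve the low number: the exchange gives a 71-fold higher number from compound 3 to compound 4 (1.85 log units; beyond the scatter) and removes most of the advantage of 4-chloro-2-methylphenyl at this aromatic carbon. The 6-fluoro-2-methylpyridin-3-yl group instead gives a 2.0-fold higher number from compound 2 to compound 4 (0.31 log units; beyond the scatter) and only a 5.0-fold lower number from compound 1 to compound 4 (0.70 log units; beyond the scatter), so both steps are modest and the new group lies much closer to 2,6-dimethylphenyl and 4-fluorophenyl than to 4-chloro-2-methylphenyl on this read-out. The low number of compound 3 therefore depends on more than the methyl group alone, and this single exchange replaces a ring carbon with nitrogen while also replacing chlorine with fluorine.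

Nothing available gives a cause for the size of this step. Open, from the compounds shown here alone, is which of the two differences carries the step, since a 4-fluoro-2-methylphenyl group or a 6-chloro-2-methylpyridin-3-yl group would each keep one of them. Also open, going by these compounds, is how a methoxy group or an amine in place of the fluorine of compound 4 would read in this assay at this position.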